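The compounds below may be only part of what the source reports. "The series", "measured", "known", "first", "only" and "open" are said of these compounds alone.

Measured so far in a functional assay on HepG2 cells (Homo sapiens) for antiproliferative activity, read by CCK-8 assay, with a stated time of 72 h, tested at 8 uM; on this read-out higher numbers stand for a stronger effect at the one concentration tested and lower numbers for a weaker effect:
- compound 1 `CC(C)n1cnc2c(Nc3cccc(Cl)c3)nc(NCOCc3ccc(C(=O)Nc4ccccc4N)cc3)nc21` gives 60.5%
- compound 2 `Nc1ccccc1NC(=O)c1ccc(Cn2cnc3c(Nc4cccc(OC(F)(F)F)c4)nc(Cl)nc32)cc1` gives 31.2%
- compound 3 `COC(CCn1cnc2c(NCc3ccc(C(=O)Nc4ccccc4N)cc3)nc(Cl)nc21)OC` gives 34.2%

Compound 3 stands second highest of the three numbers. Its nearest neighbour is compound 2, whose number is lower by a margin within the scatter, so no order can be set between these two. Compound 1 stands furthest away, higher by a margin beyond the scatter; the two structures differ in several places at once, so nothing is read from that gap about any single change.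

Compound 4 `CCCn1cnc2c(NCc3ccc(C(=O)Nc4ccccc4N)cc3)nc(Cl)nc21` is not yet measured. It differs from compound 3 in one place: methyl in place of dimethoxymethyl on a saturated chain carbon, two bonds along the chain from an aromatic nitrogen. Among the measured compounds shown here, no measured pair shows this change, so the size of the step has to be set by expectation alone. The expectation is that the step in this assay stays within the scatter, with no direction to be claimed. The step expected is a number 0.2 percentage points lower from compound 3 to compound 4 (within the scatter). Compound 4 is therefore estimated at 34%, with a range from 20% to 50%.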

Compound 4, a percentage reported as inhibition, at one concentration (the size of the read-out at that concentration, not a potency): 14.1%
Compound 4: the middle estimate sits 19.9 percentage points above what was measured; the whole stated range lies above it.
By their numbers in this assay, from the lowest: compound 4; then compounds 2 and 3 (each within the scatter of the next); then compound 1.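

In this assay the saturated chain on the aromatic nitrogen proves responsive: methyl in place of dimethoxymethyl, on a saturated chain carbon two bonds along the chain from an aromatic nitrogen, brings a number 20.1 percentage points lower from compound 3 to compound 4 (beyond the scatter) with the rest of the structure unchanged. The same difference reads as 3,3-dimethoxypropyl to propyl, so in this pair the 3,3-dimethoxypropyl compound holds the larger read-out at the one concentration tested, which is not a measure of potency. No supporting measurement bears on why the step occurs, and it remains unexplained.

The pair cannot separate the contribution of the oxygens from that of group size; a single methoxy, a hydroxyl, an amine or a carboxylic acid at this place, or a longer chain, would address that. Going by these compounds, whether the step carries over to other substituents on the shared core also remains open.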